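The source may hold more compounds than are shown below. What is called first, only, known or untested is meant among the compounds shown, and "the series" means these compounds.

Measured so far:
- compound 1 `CC1(C)OC[C@H](COc2nc(N3CCCCC3)c3nc(OC[C@H]4COC(C)(C)O4)nc(N4CCCCC4)c3n2)O1`: 62%
- compound 2 `COCC(COc1nc(N2CCCCC2)c2nc(OCC(COC)OC)nc(N3CCCCC3)c2n1)OC`: 56%
- compound 3 `OCC(O)COc1nc(N2CCCCC2)c2nc(OCC(O)CO)nc(N3CCCCC3)c2n1`: 34%

All three numbers come from a functional assay on L1210 cells (Mus musculus) for inhibition, read by thymidine incorporation, tested at 10 uM, in the presence of a further agent that is not named here; on this read-out lower numbers stand for less inhibition and higher numbers for more inhibition at the one concentration tested (going by the name of the read-out). Compound 3 gives 34%, the lowest of the three. Its nearest neighbour is compound 2, whose 56% lies higher by a gap beyond the scatter. Compound 1 is furthest from it, its 62% lying higher still, again beyond the scatter. Within the data shown here, no pair among the measured compounds differs in a single place, so no single-change step is available as a guide.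

Compound 4 `OCC(O)COc1nc(N2CCCCC2)c2nc(OC[C@@H](O)CO)nc(N3CCCCC3)c2n1` has not yet been measured. Set against compound 3 it shows (the two compounds have the same atoms and bonds; at least one stereo element is drawn with a configuration in one of them and without one in the other: 1 of 2 stereo elements differ; a stereocentre at a saturated chain carbon is drawn without a configuration in compound 3 and S in compound 4). The two share every atom and every bond; only the drawing of one stereocentre is different, one structure leaving it unassigned and the other assigning it. With nothing entering or leaving, the expected step in this assay is none beyond the scatter, in no particular direction.

Compound 4 is accordingly expected to give about 35%, within a range of 22% to 48%. The estimated step of a number 1 percentage points higher from compound 3 to compound 4 (within the scatter) is expected to stay inside the usual scatter of the read-out.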

Compound 4, a percentage reported as inhibition, at one concentration (the size of the read-out at that concentration, not a potency): 29%
Beside the measured number, compound 4's estimate is 6 percentage points above it; the range from low to high includes it.
By their numbers in this assay, from the lowest: compounds 4 and 3 (each within the scatter of the next); then compounds 2 and 1 (each within the scatter of the next).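

In this assay, the first pair differing in one place gives a number 5 percentage points lower from compound 3 to compound 4 (within the scatter), so assigning S at this saturated chain carbon produces no change beyond the scatter. The earlier compounds shown here could not show this, as no pair among them differed in a single place and the stereocentre had not been isolated as the only variable. This is not a comparison of two defined configurations, and no S against R preference can be drawn from it, because of one feature of the pair: the fact that one of compounds 3 and 4 is drawn with a defined configuration and the other without, at the place where they differ.

The compounds shown leave open how the read-out responds to the R configuration at this stereocentre, and to a defined configuration at the second stereocentre, which stays unassigned in both compound 3 and compound 4. They also leave open whether a carboxylic acid, an amine or a longer chain in this side chain would move the read-out, and how the single-concentration percentages relate to potency.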